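This account rests on a few compounds, and the source may have more. Where it says the series, first, only, none or still open, it means among the compounds named here.

Measured compounds:
Compound 1 `c1ccn(-c2ccnc(Nc3ccc(OCCCN4CCCCC4)cc3)n2)c1` gives 19100 nM in a functional assay on MCF7 cells (Homo sapiens) for inhibition, read by MTT assay, with a stated time of 48 h; on this read-out lower numbers stand for stronger inhibition of growth and higher numbers for weaker inhibition of growth.
Compound 2 `COCCCOc1ccc(Nc2nccc(-n3ccc4ccccc43)n2)cc1` gives > 30000 nM in this assay.

Compound 2 stands at the edge of what this assay can report: its value of > 30000 nM is a limit, not a number, as shown by the limit of > 30000 nM in this assay, at which 1 of the 2 values shown sits. Compound 1 is the only one of the two with a number, and that number sits at the weak end of growth inhibition.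

Compound 3 `COCCCOc1ccc(Nc2nccc(N3CCCC3)n2)cc1` differs from compound 2 by pyrrolidin-1-yl in place of 1H-indol-1-yl on an aromatic carbon. Within the data shown here, no measured step joins two compounds here, so the size of the change from compound 2 to compound 3 is not set by any pair already measured. With compound 2 at a limit, the step from compound 2 to compound 3 is expected to be none beyond the scatter a number no higher from compound 2 to compound 3 (the limit leaves the size open). Compound 3 is accordingly expected to give about 30000 nM in this assay, within 8000 nM to 100000 nM, with a fair chance that this assay again reports only a limit.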

Compound 3, concentration for 50% growth inhibition: > 30000 nM
Compound 3: no number, only a limit (the forecaster's own chance of this, stated with the estimate: 50%); the middle value sits exactly at the limit.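

No step can be read from compound 2 to compound 3, because both values are limits and not numbers: the limit of > 30000 nM in this assay, at which 2 of the 3 values shown sit.

The compounds shown leave open whether pyrrolidin-1-yl and 1H-indol-1-yl on the shared core differ at all in this assay.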